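Adding a Second Methoxy to the Shared Core

The compounds below may be only part of what the source reports. "The series", "measured", "known", "first", "only" and "open" are said of these compounds alone.

In a functional assay on cells (Splenocyte, Mus musculus, strain BALB/c) for inhibition, read by scintillation counting and thymidine incorporation, with stated times of 48 h and 8 h (a lower number here means a stronger inhibitor, a higher number a weaker inhibitor), the three measured compounds carry the same core with differing methoxy substitution. Compound 1 `COc1cccc(-c2nc(Cc3c[nH]c4ccccc34)no2)c1` gives 18500 nM. Compound 3 `COc1ccc(-c2nc(Cc3c[nH]c4ccccc34)no2)c(OC)c1` gives 8600 nM. For compound 2 `COc1ccc(-c2nc(Cc3c[nH]c4ccccc34)no2)cc1` the assay reports only a limit, > 50000 nM, shown as the limit of > 50000 nM in this assay, at which 1 of the 3 values shown sits. Compound 1 and compound 2 have the same atoms joined differently; the difference between the two cores is not broken down here. From compound 2 to compound 3 the change is methoxy in place of hydrogen on an aromatic carbon, and it brought an at least 5.8-fold lower number from compound 2 to compound 3 (0.76 log units; beyond the scatter).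

Compound 4 `COc1ccc(OC)c(-c2nc(Cc3c[nH]c4ccccc34)no2)c1` is not yet measured. It differs from compound 1 by methoxy in place of hydrogen on an aromatic carbon, the same kind of change as that from compound 2 to compound 3, though the place differs: para to a methoxy group in compound 4 against meta to a methoxy group in compound 3. Given that compound 1 gives 18500 nM and that the earlier step was an at least 5.8-fold lower number from compound 2 to compound 3 (0.76 log units; beyond the scatter), the expected step is a 3.1-fold lower number from compound 1 to compound 4 (0.49 log units; beyond the scatter). Compound 4 is therefore estimated at 6000 nM, between 2000 nM and 20000 nM.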

Compound 4, half-maximal inhibitory concentration: > 50000 nM
Compound 4 ended at the assay's limit (the forecaster's own chance of this, stated with the estimate: 5%); middle value at least 8.3-fold (0.92 log units) from the limit.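

In this assay, methoxy in place of hydrogen on an aromatic carbon did not carry over from one core to the other, and the two steps run in opposite directions: the same change on two cores in this assay, an at least 5.8-fold lower number (0.76 log units; beyond the scatter) from compound 2 to compound 3 and an at least 2.7-fold higher number (0.43 log units; beyond the scatter) from compound 1 to compound 4, at least 15-fold (1.19 log units) apart, beyond the scatter of two such steps. The new step is an at least 2.7-fold higher number from compound 1 to compound 4 (0.43 log units; beyond the scatter), and its end point is only a limit, shared with one other compound: the limit of > 50000 nM in this assay, at which 2 of the 4 values shown sit. The added methoxy in compound 4 sits ortho to a large group and para to a methoxy group, and two cases do not show whether that place or the core decides the outcome, nor how large either step truly is.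

The compounds shown leave open whether the same change at another place on the core of compound 1 would also lower the number. They also leave open how this ring responds to groups other than methoxy, such as a hydroxyl, a fluorine or an amine, or to a longer chain on the oxygen, such as ethoxy.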